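The source may hold more compounds than are shown below. What is called first, only, known or untested is meant among the compounds shown, and "the series" means these compounds.

Measured compounds:
compound 1 `O=c1[nH]c(=O)n([C@H]2C[C@H](O)[C@@H](CO)O2)cc1/C=C/I` — 63900 nM
compound 2 `N#Cc1cn([C@H]2C[C@H](O)[C@@H](CO)O2)c(=O)[nH]c1=O` — a limit of the assay, > 200000 nM
compound 3 `O=c1[nH]c(=O)n([C@H]2C[C@H](O)[C@@H](CO)O2)cc1C1SCCS1` — a limit of the assay, > 200000 nM

In an ADME assay on L1210/0 cells (Mus musculus) for cytotoxicity, with a stated time of 48 h (on this read-out lower numbers stand for stronger inhibition and higher numbers for weaker inhibition), compound 1 gives 63900 nM. Compound 3 reaches only the limit, > 200000 nM. Compound 3 thus stands at the weak end of the three, and two of the values sit at the limit of > 200000 nM in this assay, at which 2 of the 3 values shown sit. The readable steps are an at least 3.1-fold higher number from compound 1 to compound 2 (0.49 log units; beyond the scatter) and an at least 3.1-fold higher number from compound 1 to compound 3 (0.49 log units; beyond the scatter); the step that the two limits leave unreadable from compound 2 to compound 3 is not readable. Compound 4 `CC(C)(C)C#Cc1cn([C@H]2C[C@H](O)[C@@H](CO)O2)c(=O)[nH]c1=O` differs from compound 3 by a group of 6 heavy atoms (6 carbon; no ring) in place of a group of 5 heavy atoms (3 carbon, 2 sulfur; one five-membered non-aromatic ring with 2 hetero atoms), on an aromatic carbon. Among the measured compounds shown here, no measured step bears directly on this exchange, so the expected step of an at least 2.0-fold lower number from compound 3 to compound 4 (0.30 log units; that floor lies within the scatter) is small and uncertain in direction. Compound 4 is expected to give 100000 nM, between 20000 nM and 250000 nM.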

Compound 4, half-maximal inhibitory concentration: > 200000 nM
Compound 4 ended at the assay's limit; the forecaster's own chance of this, stated with the estimate: 45%; middle value at least 2.0-fold (0.30 log units) from the limit.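

In this assay, 3,3-dimethylbut-1-yn-1-yl in place of 2-iodoethenyl gives an at least 3.1-fold higher number from compound 1 to compound 4 (0.49 log units; beyond the scatter). Compound 4 gives only a limit of the assay, > 200000 nM. A group of carbon alone thus joins the cyano group and the sulfur-containing ring at this aromatic carbon, compound 1 remains the only one with a number, and the steps among compound 2, compound 3 and compound 4 cannot be read: the limit of > 200000 nM in this assay, at which 3 of the 4 values shown sit.

The compounds shown leave open how far those three lie past the limit. They also leave open whether an ethyl chain or a bromine atom at this carbon would give a number, as the 2-iodoethenyl group of compound 1 does.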